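Adding a (trifluoromethyl)sulfonyl group to compound 1

The source may report more compounds than this note shows. Statements on the series, on what has been measured and on what is new or still open speak of the compounds shown alone.

Measured compounds:
compound 1, `CN(C)CC[C@H](CSc1ccccc1)Nc1ccc(S(=O)(=O)NC(=O)c2ccc(N3CCN(Cc4ccccc4-c4ccc(Cl)cc4)CC3)cc2)cc1`, 78700 nM
compound 2, `O=C(NS(=O)(=O)c1ccc(NCCSc2ccccc2)c([N+](=O)[O-])c1)c1ccc(N2CCN(Cc3ccccc3-c3ccc(Cl)cc3)CC2)cc1`, 33000 nM

In a functional assay on NCI-H146 cells (Homo sapiens) for cytotoxicity, with a stated time of 48 h, in the presence of a further agent that is not named here (a lower number here means that less compound is needed, a higher number that more compound is needed for the effect), compound 1 gives 78700 nM, the highest number of the two measured compounds. The nearest value belongs to compound 2, which in this assay gives 33000 nM, a lower number that lies beyond the usual scatter, so compound 1 needs more material than compound 2 for the same effect.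

Compound 3, `CN(C)CC[C@H](CSc1ccccc1)Nc1ccc(S(=O)(=O)NC(=O)c2ccc(N3CCN(Cc4ccccc4-c4ccc(Cl)cc4)CC3)cc2)cc1S(=O)(=O)C(F)(F)F`, has not been measured in this assay. It differs from compound 1 in one place: (trifluoromethyl)sulfonyl in place of hydrogen on an aromatic carbon. Among the measured compounds shown here, no step between two measured compounds shows what this change does, and compound 2 differs from compound 1 in more than one way, so only the values of compound 1 and compound 2 can be read side by side.

Compound 3 is expected to need less material than compound 1, with a step of a 9.8-fold lower number from compound 1 to compound 3 (0.99 log units; beyond the scatter) in this assay that goes beyond the scatter. The expected value for compound 3 in this assay is 8000 nM, with a range from 1500 nM to 40000 nM.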

Compound 3, half-maximal effective concentration: 39.4 nM
For compound 3 the middle estimate is 200-fold (2.31 log units) above the measured one, and the stated range ends above it.
By their numbers in this assay, from the lowest: compound 3; then compound 2; then compound 1.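

In this assay, putting (trifluoromethyl)sulfonyl in place of hydrogen on this aromatic carbon gives a 2000-fold lower number from compound 1 to compound 3 (3.30 log units; beyond the scatter), a large step from one substituent of 7 heavy atoms with no ring and no net charge. Compound 1 and compound 2 differ in more than one way, so their values could not tie any effect to this place; the new pair shows that in this assay the number depends strongly on what this carbon, ortho to a large group and meta to a large group, carries. Nothing measured here accounts for the size of this step.

Going by these compounds, it remains open whether the step is particular to (trifluoromethyl)sulfonyl or would also appear with another group on the same carbon, such as a nitrile, a methylsulfonyl group or a carboxylic acid. On these data alone, it is equally open whether a step of this size would persist if the dimethylamino group of the shared core gave way to a morpholine, or if its chain were shortened.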